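Ring contraction on the urea side: piperidine to azetidine

This account rests on a few compounds, and the source may have more. Where it says the series, first, only, none or still open, it means among the compounds named here.

Compound 1 `CC(C)CC1(O)CCN(C(=O)Nc2cc(Oc3ccc(F)cc3)cc(Oc3ccc(C(C)(C)C(=O)O)cc3)c2)CC1` carries a hydroxy-isobutylpiperidine on the urea carbonyl. In an ADME assay on the whole organism for pharmacokinetics, with Rattus norvegicus as the target, at a dose of 1 mg/kg by the oral route (a higher number here means more compound in the circulation at the dose given, a lower number less compound in the circulation), compound 1 gives 156 nM. Compound 2 `CC(C)CC1(O)CCN(C(=O)Nc2cc(Oc3ccc(F)cc3)cc(Oc3ccc(C4(C(=O)O)CC4)cc3)c2)CC1` differs only in the acid-bearing group on the aromatic ring, and in this assay compound 2 gives 110 nM; the step of a 1.4-fold lower number from compound 1 to compound 2 (0.15 log units; within the scatter) means the two compounds cannot be told apart on these numbers. Compound 3 `CC(C)CC1(O)CN(C(=O)Nc2cc(Oc3ccc(F)cc3)cc(Oc3ccc(C(C)(C)C(=O)O)cc3)c2)C1` is the new compound, with 3-hydroxy-3-isobutylazetidin-1-yl in place of 4-hydroxy-4-isobutylpiperidin-1-yl on a carbonyl carbon. For the measured compounds named here, no measured step touches this part of the molecule; the only step on record, from compound 1 to compound 2, sits at the acid end and was within the scatter, so nothing here points in either direction. On these data alone, the expectation for compound 3 is therefore a step of a 1.2-fold lower number from compound 1 to compound 3 (0.08 log units; within the scatter), with a wide range because the change is untested. Compound 3 is estimated at 130 nM, between 40 nM and 420 nM.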

Compound 3, maximal plasma concentration: 738 nM
The estimate for compound 3 lay 5.7-fold (0.75 log units) below the measured number, and the stated range ends below it.
By their numbers in this assay, from the lowest: compounds 2 and 1 (each within the scatter of the next); then compound 3.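

For the compounds shown here, this is the first step at the urea end of the molecule, and unlike the earlier step at the acid end, it moves the number clearly: in this assay the change from the six-membered to the four-membered ring gives a 4.7-fold higher number from compound 1 to compound 3 (0.67 log units; beyond the scatter) at the same oral dose. The hydroxy and isobutyl groups stay in both compounds, so this single pair links the smaller ring with more compound in the circulation. Nothing available explains why the smaller ring goes with the higher number.

The compounds shown leave open whether the higher number carries over when the 3-hydroxy-3-isobutylazetidin-1-yl group is paired with the 1-carboxycyclopropyl group of compound 2. They also leave open how a five-membered pyrrolidine ring, or an amine in place of the hydroxy group, would read in this assay.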